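A few compounds are considered here, and "the series" means these few. Any claim that something is new, unique, unknown or untested is made for them only; others in the source may bear on it.

Measured compounds: compound 1 `CC(C)(C)C[N+]1(C)CCc2c(sc(NC(=O)Nc3ccc(Cl)cc3)c2C(N)=O)C1`, 290 nM; compound 2 `CC1(C)Cc2c(sc(NC(=O)Nc3ccc(Cl)cc3)c2C(N)=O)C(C)(C)N1`, 1240 nM; compound 3 `CC(C)(C)OC(=O)CCC[N+]1(C)CCc2c(sc(NC(=O)Nc3ccc(Cl)cc3)c2C(N)=O)C1`, 250 nM, all in a functional assay (strain AB) with Danio rerio as the target, read by microscopy, with a stated time of 1 h; a higher number here means that more compound is needed for the effect, a lower number that less compound is needed.

Compound 3 holds the lowest of the three numbers, but compound 1 sits within the scatter of it, while compound 2 lies beyond the scatter above it. Compound 4 `CC(C)(C)OC(=O)CCCC[N+]1(C)CCc2c(sc(NC(=O)Nc3ccc(Cl)cc3)c2C(N)=O)C1` differs from compound 3 by (tert-butoxycarbonyl)methyl in place of tert-butoxycarbonyl on a saturated chain carbon, three bonds along the chain from an amine nitrogen in a ring. Within the data shown here, the one measured step that bears on this kind of change is a 1.2-fold lower number from compound 1 to compound 3 (0.06 log units; within the scatter), a lengthening on the same ring nitrogen that left the number essentially unchanged. Compound 4 is therefore expected to stay within the scatter of compound 3, with an estimated step of a 1.0-fold higher number from compound 3 to compound 4 (0.02 log units; within the scatter). The expected value for compound 4 is 260 nM, in a range of 130 nM to 520 nM.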

Compound 4, half-maximal effective concentration: 140 nM
For compound 4 the middle estimate is 1.9-fold (0.27 log units) above the measured one; low and high end bracket the measured number.
By their numbers in this assay, from the lowest: compounds 4, 3 and 1 (each within the scatter of the next, the first and the last beyond it); then compound 2.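

In this assay the change of tert-butoxycarbonyl to (tert-butoxycarbonyl)methyl, on the saturated chain carbon three bonds along the chain from an amine nitrogen in a ring, gives a 1.8-fold lower number from compound 3 to compound 4 (0.25 log units; within the scatter) and so stays within the usual scatter. The longer ester chain does, however, give the first step among these quaternary compounds to pass the scatter, though only modestly, with a 2.1-fold lower number from compound 1 to compound 4 (0.32 log units; beyond the scatter) in the same assay. No available evidence explains this difference.

As far as these compounds go, whether a still longer chain would shift the number further remains open. So does the effect of a carboxylic acid in place of the tert-butyl ester.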